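This account rests on a few compounds, and the source may have more. Where it says the series, first, only, none or still open, it means among the compounds named here.

Compound 1 `CC(=O)Oc1ccccc1/C=C/c1nc2ccccc2c(=O)[nH]1`: > 25000 nM
Compound 2 `CC(=O)Oc1ccccc1/C=C/c1nc(Nc2ccccc2I)c2ccccc2n1`: 15600 nM

Both compounds were tested in a functional assay on MCF7 cells (Homo sapiens) for antiproliferative activity, with a stated time of 72 h; a higher number here means a weaker inhibitor, a lower number a stronger inhibitor. Compound 1 gives > 25000 nM, and this is a limit of the assay, not a number. Its standing is thus (the limit of > 25000 nM in this assay, at which 1 of the 2 values shown sits). Among the measured compounds shown here, compound 2 gives 15600 nM, but it differs from compound 1 in more than one place, so the two values define no single structural step.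

Compound 3 `CC(=O)Oc1ccc(/C=C/c2nc3ccccc3c(=O)[nH]2)c(OC(C)=O)c1` keeps the core of compound 1 and carries acetoxy in place of hydrogen on an aromatic carbon, meta to an acetoxy group and para to a large group: acetoxy in place of hydrogen on an aromatic carbon. For the measured compounds named here, no measured step guides its size, so only a small shift towards stronger inhibition is expected in this assay, the estimated at least 1.2-fold lower number from compound 1 to compound 3 (0.09 log units; that floor lies within the scatter), and it may not exceed the scatter. Compound 3 is estimated at 20000 nM. The expected range for compound 3 runs from 7000 nM to 50000 nM.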

Compound 3, half-maximal inhibitory concentration: > 25000 nM
Compound 3: only a limit was reported (the forecaster's own chance of this, stated with the estimate: 55%); middle value at least 1.2-fold (0.09 log units) away from the limit.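

In this assay compound 3 gives > 25000 nM, a limit and not a number, as compound 1 also does, so no step between them can be read: the limit of > 25000 nM in this assay, at which 2 of the 3 values shown sit.

The compounds shown leave open whether acetoxy in place of hydrogen on an aromatic carbon changes the inhibition at all.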